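The compounds below may be only part of what the source reports. "The series", "measured", "known", "first", "only" and "open" are said of these compounds alone.

Measured in a functional assay on Jurkat cells for inhibition of nuclear factor NF-kappa-B complex (Homo sapiens); a lower number here means a stronger inhibitor, a higher number a weaker inhibitor:

Compound 1 `CCOC(=O)c1cnc(C(F)(F)F)nc1NN1C(=O)C=C(C)C1=O`: 1000 nM
Compound 2 `CCOC(=O)c1cnc(CC)nc1NN1C(=O)C=C(C)C1=O`: 10000 nM
Compound 3 `CCOC(=O)c1cnc(-c2ccc(C(F)(F)F)cc2)nc1NN1C(=O)C=C(C)C1=O`: 400 nM

Compound 2 has the highest number of the three, that is, it is the weakest inhibitor of the set. The nearest number is one step away, a 10-fold higher number from compound 1 to compound 2 (1.00 log units; beyond the scatter), and the furthest is a 25-fold lower number from compound 2 to compound 3 (1.40 log units; beyond the scatter). All three share one core and differ only in the group at a single aromatic carbon.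

Compound 4 `CCOC(=O)c1cnc(-c2ccc(C)s2)nc1NN1C(=O)C=C(C)C1=O` has not yet been measured in this assay. Its structure differs from compound 2 in one place:

5-methylthiophen-2-yl in place of ethyl on an aromatic carbon

The measured step that bears most directly on this change is a 25-fold lower number from compound 2 to compound 3 (1.40 log units; beyond the scatter), in which an aromatic ring likewise took the place of the ethyl group at the same carbon. The step of a 2.5-fold lower number from compound 1 to compound 3 (0.40 log units; beyond the scatter) also points the same way, an aromatic ring at this carbon going with a lower number. On this basis a large step downward in this assay is expected, roughly a 14-fold lower number from compound 2 to compound 4 (1.15 log units; beyond the scatter), though a ring of a different kind may not reach quite as far as compound 3. Compound 4 is therefore estimated at 700 nM, with a likely range from 200 nM to 2500 nM.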

Compound 4, half-maximal inhibitory concentration: 200 nM
Estimate against measurement, compound 4: 3.5-fold (0.54 log units) above; low and high end bracket the measured number.
By their numbers in this assay, from the lowest: compounds 4 and 3 (each within the scatter of the next); then compound 1; then compound 2.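

Up to now, only one aromatic ring had been seen at this carbon in this assay and so the drop from ethyl might have been special to 4-(trifluoromethyl)phenyl; the new result (a 50-fold lower number from compound 2 to compound 4 (1.70 log units; beyond the scatter)) shows that a second aromatic ring of a different kind, 5-methylthiophen-2-yl, also gives a large drop. The five-membered ring with its sulfur and the six-membered ring carrying trifluoromethyl cannot be told apart here (a 2.0-fold lower number from compound 3 to compound 4 (0.30 log units; within the scatter)), so swapping one for the other made no change beyond the scatter. For the compounds shown here, the new ring also improves on the trifluoromethyl group (a 5.0-fold lower number from compound 1 to compound 4 (0.70 log units; beyond the scatter)), which means that across these four compounds both aromatic rings give lower numbers than both non-ring groups, with no compound going against this.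

No measurement shown here explains why an aromatic ring at this carbon goes with stronger inhibition. Still open, on these data alone, is how a plain phenyl, a thiophen-2-yl without its methyl, a longer chain such as butyl, or an amine such as morpholine would compare at the same carbon.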